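Phenyl added to the sulfur-bound carbon of compound 3

The compounds below may be only part of what the source reports. "The series", "measured", "known", "first", "only" and "open" are said of these compounds alone.

Compounds measured so far:
compound 1, `Cc1nnc(SCc2ccccc2)n1N1C(=O)c2ccccc2C1=O`: > 200000 nM
compound 2, `COc1cc(-c2nnc(SCC(=O)c3ccc(Cl)cc3)n2N2C(=O)c3ccccc3C2=O)cc(OC)c1OC`: 9030 nM
compound 3, `COc1cc(-c2nnc(SC)n2N2C(=O)c3ccccc3C2=O)cc(OC)c1OC`: > 200000 nM

In a functional assay on A549 cells (Homo sapiens) for cytotoxicity, read by MTT assay, with a stated time of 48 h (a higher number here means a weaker inhibitor, a lower number a stronger inhibitor), compound 2 gives 9030 nM. For compound 3 only a limit is known, > 200000 nM. Compound 1 likewise sits at a limit, > 200000 nM. Among the values shown, (the limit of > 200000 nM in this assay, at which 2 of the 3 values shown sit), so compound 3 stands at the weak end of what is known. Compound 4, `COc1cc(-c2nnc(SCc3ccccc3)n2N2C(=O)c3ccccc3C2=O)cc(OC)c1OC`, differs from compound 3 by phenyl in place of hydrogen on a saturated chain carbon bound to a sulfur. Going by the values given here, the one measured step at this place is an at least 22-fold higher number from compound 2 to compound 3 (1.34 log units; beyond the scatter), where losing the (4-chlorophenyl)carbonyl gave a much higher number. Restoring an aromatic ring there is therefore expected to lower the number, though the group differs from that in compound 2, and compound 1, which carries the same benzylsulfanyl group, also sits at a limit. The expected step is an at least 3.3-fold lower number from compound 3 to compound 4 (0.52 log units; beyond the scatter). Compound 4 is estimated at 60000 nM, between 10000 nM and 200000 nM.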

Compound 4, half-maximal inhibitory concentration: > 200000 nM
Compound 4: only a limit was reported; the forecaster's own chance of this, stated with the estimate: 45%; at least 3.3-fold (0.52 log units) between middle value and limit.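

In this assay, phenyl on the saturated chain carbon bound to a sulfur does not match the (4-chlorophenyl)carbonyl group of compound 2: an at least 22-fold higher number from compound 2 to compound 4 (1.34 log units; beyond the scatter). An aromatic ring on this carbon is thus not enough on the shared core to bring the number off the limit. The steps from compound 3 to compound 4 and from compound 1 to compound 4 cannot be read, and only compound 2 has a value that is not a limit: the limit of > 200000 nM in this assay, at which 3 of the 4 values shown sit.

From the compounds shown here alone, what stays open is whether the carbonyl or the chlorine accounts for the difference from compound 2. A 4-chlorobenzyl group or a plain benzoyl group on this carbon would separate the two.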